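The compounds below may be only part of what the source reports. "The series", "measured", "known", "first", "only" and "open" are said of these compounds alone.

Compound 2 `O=C(Nc1c(C(O)(C(F)(F)F)C(F)(F)F)ccc2ccccc12)c1cc(Cl)cc(Cl)c1` stands at the lower end of the two numbers seen so far in an assay on LtK cells with ATP-sensitive inward rectifier potassium channel 11 (Homo sapiens) as the target (on this read-out lower numbers stand for an effect already at smaller amounts and higher numbers for an effect only at larger amounts of compound), where compound 2 gives 306 nM. Within the data shown here, its only measured neighbour is compound 1 `O=C(Nc1c(C(O)(C(F)(F)F)C(F)(F)F)ccc2ccccc12)C1CC1`, which in this assay gives 751 nM. Among the measured compounds shown here, the single measured step, a 2.5-fold lower number from compound 1 to compound 2 (0.39 log units; beyond the scatter), is the one change from which anything can be read: a six-membered aromatic ring of carbon only on the carbonyl carbon gave a lower number than cyclopropyl there.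

Compound 3 `O=C(Nc1c(C(O)(C(F)(F)F)C(F)(F)F)ccc2ccccc12)c1cccnc1` differs from compound 2 in pyridin-3-yl in place of 3,5-dichlorophenyl on a carbonyl carbon. For the measured compounds named here, no measured step covers an exchange of one six-membered aromatic ring for another on that carbonyl carbon, so the measured step bears on it only indirectly, by showing that an aromatic ring at that place is compatible with a lower number than the cyclopropyl of compound 1. Going by the values given here, with one pyridin-3-yl ring in place of the 3,5-dichlorophenyl, and no closer precedent, a modest rise is expected, and in this assay the estimated step is a 2.1-fold higher number from compound 2 to compound 3 (0.33 log units; beyond the scatter). Compound 3 is therefore expected to give 650 nM in this assay, within a range from 250 nM to 1700 nM.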

Compound 3, half-maximal effective concentration: 60 nM
Compound 3: middle estimate off by 11-fold (1.03 log units), on the high side, and the stated range ends above it.
By their numbers in this assay, from the lowest: compound 3; then compound 2; then compound 1.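

The exchange of 3,5-dichlorophenyl for pyridin-3-yl on the carbonyl carbon gives in this assay a 5.1-fold lower number from compound 2 to compound 3 (0.71 log units; beyond the scatter) and so shows that this position distinguishes one six-membered aromatic ring from another, which the earlier pair, an aromatic ring against cyclopropyl, could not show. Measured against the cyclopropyl of compound 1, the new ring gives a 13-fold lower number from compound 1 to compound 3 (1.10 log units; beyond the scatter) and places compound 3 lowest of the three, so the number here depends on the make-up of the aromatic ring and not merely on an aromatic ring being present. Nothing available bears on what lies behind this drop.

The exchange removes both chlorine atoms and brings in the ring nitrogen in a single change, so the compounds shown do not separate these two differences, and an unsubstituted phenyl ring at this place would speak to that. They also leave open whether the place of the ring nitrogen matters, as pyridin-2-yl or pyridin-4-yl would show, and whether an amine on the pyridine ring is tolerated.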